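Two Limits and a Third Amide Variant

A few compounds are considered here, and "the series" means these few. Any claim that something is new, unique, unknown or untested is made for them only; others in the source may bear on it.

Compound 1 `CCN(CC)S(=O)(=O)c1ccc(S(=O)(=O)N2CCC[C@@H](C(=O)NC3COC3)C2)cc1` carries an oxetan-3-yl group on the amide-type nitrogen of the shared core. In a functional assay on MIA PaCa-2 cells (Homo sapiens) for inhibition, read by MTT assay, with a stated time of 3 days (on this read-out lower numbers stand for stronger inhibition and higher numbers for weaker inhibition), compound 1 gives only a limit, > 10000 nM. Compound 2 `CCN(CC)S(=O)(=O)c1ccc(S(=O)(=O)N2CCC[C@@H](C(=O)NC3CN(C(=O)NC(C)(C)C)C3)C2)cc1` has 1-((tert-butyl)carbamoyl)azetidin-3-yl in that place. In this assay compound 2 likewise gives only a limit, > 10000 nM. The step that the two limits leave unreadable from compound 1 to compound 2 is therefore not readable, and compound 2 stands at the limit of > 10000 nM in this assay, at which 2 of the 2 values shown sit. Compound 3 `CCN(CC)S(=O)(=O)c1ccc(S(=O)(=O)N2CCC[C@@H](C(=O)N[C@H]3CCN(C(=O)OC(C)(C)C)C3)C2)cc1` differs from compound 2 by 1-(tert-butoxycarbonyl)pyrrolidin-3-yl in place of 1-((tert-butyl)carbamoyl)azetidin-3-yl on an amide-type nitrogen. Among the compounds with values here, only the step from compound 1 to compound 2 bears on this change, and it left both ends at the limit, so no size can be taken from it. Compound 3 is expected to give about 15000 nM, within 5000 nM to 50000 nM, most likely again as a limit only. The step that the limit leaves unreadable from compound 2 to compound 3 is expected to remain within the scatter.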

Compound 3, half-maximal inhibitory concentration: > 10000 nM
Compound 3 was reported as a limit; the forecaster's own chance of this, stated with the estimate: 85%; the middle value is on the limit's open side.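

No step among compound 1, compound 2 and compound 3 can be read, as compound 3 is also only a limit: the limit of > 10000 nM in this assay, at which 3 of the 3 values shown sit.

The compounds shown leave open whether any group on the amide-type nitrogen of the shared core gives a measurable value in this assay.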